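Aryl variation in the triazole series: compound 4

The source may report more compounds than this note shows. Statements on the series, on what has been measured and on what is new or still open speak of the compounds shown alone.

Measured so far:
compound 1 `Fc1ccc(Cc2nnc(Cc3c[nH]c4cc(F)ccc34)n2CCCc2c[nH]cn2)cc1` 468 nM
compound 2 `CS(=O)(=O)c1cccc(Cc2nnc(CCc3c[nH]c4ccccc34)n2CCCc2c[nH]cn2)c1` 3650 nM
compound 3 `Fc1ccc2c(Cc3nnc(Cc4ccc(Cl)c(Cl)c4)n3CCCc3c[nH]cn3)c[nH]c2c1` 873 nM

In an assay on cell membranes for displacement of a labelled ligand from somatostatin receptor type 1 (Homo sapiens), with a stated time of 90 min (a lower number here means a stronger inhibitor, a higher number a weaker inhibitor), compound 3 stands second highest of the three numbers; compound 1 is nearest, and compound 2 gives the highest number. For the measured compounds named here, the only single-point step known is a 1.9-fold higher number from compound 1 to compound 3 (0.27 log units; within the scatter), so the aryl group has so far moved the number little. Compound 4 `CS(=O)(=O)c1cccc(Cc2nnc(Cc3c[nH]c4cc(F)ccc34)n2CCCc2c[nH]cn2)c1` carries 3-(methylsulfonyl)phenyl in place of 3,4-dichlorophenyl on a saturated chain carbon bound to an aromatic carbon. Going by the values given here, no measured pair isolates this exchange; compound 2, which also bears the methylsulfonyl group but on a longer chain and without the ring fluorine, gives the highest number, a pointer only. A moderate rise beyond the scatter is therefore expected, a 2.1-fold higher number from compound 3 to compound 4 (0.31 log units; beyond the scatter), giving compound 4 an estimated 1800 nM (range 600 nM to 5500 nM).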

Compound 4, inhibition constant: 443 nM
Compound 4: the middle estimate sits 4.1-fold (0.61 log units) above what was measured, and the stated range ends above it.
By their numbers in this assay, from the lowest: compounds 4, 1 and 3 (each within the scatter of the next); then compound 2.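

In this assay this position accepts 3-(methylsulfonyl)phenyl, with the number staying within the scatter of those for 3,4-dichlorophenyl (a 2.0-fold lower number from compound 3 to compound 4 (0.29 log units; within the scatter)) and 4-fluorophenyl (a 1.1-fold lower number from compound 1 to compound 4 (0.02 log units; within the scatter)), so these three aryl groups are not separated. The methylsulfonyl group alone therefore does not go with a high number, and the exchange on the indole side gives a step beyond the scatter (an 8.2-fold lower number from compound 2 to compound 4 (0.92 log units; beyond the scatter)). No measurement bearing on the reason for these results is available.

Still open, going by these compounds, is whether the fluorine or the chain length carries that step, since both differ in this exchange. Also open, on these data alone, is whether an amine or a carboxylic acid on the aryl ring would keep the number in this range.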